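The source may report more compounds than this note shows. Statements on the series, on what has been measured and on what is new or still open speak of the compounds shown alone.

Values in a functional assay on A549 cells (Homo sapiens) for cytotoxicity, read by MTT assay, with a stated time of 72 h (a lower number here means a stronger inhibitor, a higher number a weaker inhibitor), for the measured compounds:
compound 1 `CN(C)CCn1cnnc1-c1cc(Oc2ccc(NC(=O)N/N=C/c3ccc(Cl)cc3Cl)cc2F)ccn1` — 810 nM
compound 2 `CN(C)CCn1cnnc1-c1cc(Oc2ccc(NC(=O)N/N=C/c3ccc(F)cc3)cc2F)ccn1` — 1790 nM
compound 3 `CN(C)CCn1cnnc1-c1cc(Oc2ccc(NC(=O)N/N=C/c3cccc(Cl)c3Cl)cc2F)ccn1` — 1090 nM

Compound 2 gives the highest number of the three. Its nearest neighbour is compound 3, the step of a 1.6-fold lower number from compound 2 to compound 3 (0.22 log units; within the scatter) lying within the scatter; the furthest is compound 1, with a 2.2-fold higher number from compound 1 to compound 2 (0.34 log units; beyond the scatter) beyond it. Compound 4 `CN(C)CCn1cnnc1-c1cc(Oc2ccc(NC(=O)N/N=C/c3ccc(O)c(F)c3)cc2F)ccn1` is not yet measured; its change from compound 2 is 3-fluoro-4-hydroxyphenyl in place of 4-fluorophenyl on a carbon with a double bond to nitrogen. Every measured step varies the aryl on the carbon with a double bond to nitrogen, and the steps of a 2.2-fold higher number from compound 1 to compound 2 (0.34 log units; beyond the scatter), a 1.3-fold higher number from compound 1 to compound 3 (0.13 log units; within the scatter) and a 1.6-fold lower number from compound 2 to compound 3 (0.22 log units; within the scatter) are at most modest; none places a 3-fluoro-4-hydroxyphenyl there. A step within or near the scatter is therefore expected in this assay. Compound 4 is estimated at 1400 nM, within 600 nM to 3500 nM. This estimate means an expected step of a 1.3-fold lower number from compound 2 to compound 4 (0.11 log units; within the scatter).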

Compound 4, half-maximal inhibitory concentration: 13400 nM
Compound 4: middle estimate off by 9.6-fold (0.98 log units), on the low side; measured number above the stated range.
By their numbers in this assay, from the lowest: compounds 1, 3 and 2 (each within the scatter of the next, the first and the last beyond it); then compound 4.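

In this assay this position can carry a step well beyond the scatter: 3-fluoro-4-hydroxyphenyl in place of 4-fluorophenyl gives (a 7.5-fold higher number from compound 2 to compound 4 (0.87 log units; beyond the scatter)), more than any step among the three halogen-only aryls. Against the two dichlorophenyl compounds, the same group gives (a 12-fold higher number from compound 3 to compound 4 (1.09 log units; beyond the scatter)) and (a 17-fold higher number from compound 1 to compound 4 (1.22 log units; beyond the scatter)), so all three steps to compound 4 run in one direction. Nothing available gives a cause for this change.

Open, going by these compounds, is which part of the 3-fluoro-4-hydroxyphenyl carries the step. A 4-hydroxyphenyl or 4-methoxyphenyl on this carbon would test the hydroxyl directly, and a 4-aminophenyl would show whether another group of that kind behaves alike.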